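Two Compounds at the Assay Limit, and a Hydroxy Swap

The source may hold more compounds than are shown below. What is called first, only, known or untested is meant among the compounds shown, and "the series" means these compounds.

Measured in a functional assay on PC-3 cells (Homo sapiens) for antiproliferative activity, read by XTT assay; on this read-out higher numbers stand for weaker inhibition and lower numbers for stronger inhibition:
- Compound 1 `O=c1c(/C=C/c2coc3ccccc3c2=O)coc2ccccc12`: > 10000 nM
- Compound 2 `O=c1c(Cc2coc3cccc(OCC4CCCCC4)c3c2=O)coc2cc(Cl)ccc12`: > 10000 nM

Both entries are limits of the assay, not numbers. Compound 2 stands at the limit of > 10000 nM in this assay, at which 2 of the 2 values shown sit. Compound 3 `O=c1c(Cc2coc3cccc(OCC4CCCCC4)c3c2=O)coc2cc(O)ccc12` carries hydroxy in place of chloro on an aromatic carbon of a six-membered aromatic ring of carbon only (hydroxy in place of chloro on an aromatic carbon). Among the compounds with values here, no measured step shows what this change does in this assay, so only a small move toward stronger inhibition is expected, and another limit is quite possible. The expected change is small, given as an at least 1.2-fold lower number from compound 2 to compound 3 (0.09 log units; that floor lies within the scatter). Compound 3 is estimated at 8000 nM, with an expected range from 2500 nM to 25000 nM.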

Compound 3, half-maximal inhibitory concentration: 4250 nM
Compound 3: middle estimate off by 1.9-fold (0.27 log units), on the high side; the measured number falls inside the stated range.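

In this assay, putting hydroxy in place of chloro on this aromatic carbon gives the first measurable number among the compounds shown, with an at least 2.3-fold lower number from compound 2 to compound 3 (0.37 log units; beyond the scatter). This shows that the change at this position can move the read-out, which the two earlier entries could not show. The entry for compound 2 is a limit, not a number, so the true size of the step stays unknown: the limit of > 10000 nM in this assay, at which 2 of the 3 values shown sit.

From the compounds shown here alone, whether hydroxy itself is needed remains open. An amine or a methoxy group on the same carbon would test this.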